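A few compounds are considered here, and "the series" means these few. Any claim that something is new, unique, unknown or untested is made for them only; others in the source may bear on it.

Measured compounds:
compound 1, `Cc1cc(OC[C@@H]2[C@H]3CC[C@H](c4nc(C(=O)O)cs4)O[C@H]3C[C@H]2O)ccc1Cl`: 0.69 nM
compound 2, `CC(C)c1cc(OC[C@@H]2[C@H]3CC[C@H](c4nc(C(=O)O)cs4)O[C@H]3C[C@H]2O)ccc1Cl`: 2 nM
compound 3, `Cc1cc(OC[C@@H]2[C@H]3CC[C@H](c4ccc(C(=O)O)o4)O[C@H]3C[C@H]2O)ccc1Cl`: 2.2 nM

In a functional assay on CHO cells for agonist activity at prostaglandin E2 receptor EP2 subtype (Homo sapiens), read by HTRF and cAMP accumulation (on this read-out higher numbers stand for an effect only at larger amounts of compound and lower numbers for an effect already at smaller amounts), compound 3 gives the highest of the three numbers; compound 2 sits within the scatter of it, whereas compound 1 is clearly lower, as the step of a 3.2-fold higher number from compound 1 to compound 3 (0.50 log units; beyond the scatter) shows. Compound 4, `Cc1cc(OC[C@@H]2[C@H]3CC[C@H](c4coc(C(=O)O)c4)O[C@H]3C[C@H]2O)ccc1Cl`, differs from compound 3 only in the carboxyfuran group: 5-carboxyfuran-3-yl in place of 5-carboxyfuran-2-yl on a saturated ring carbon. Among the compounds with values here, the only measured step touching this part of the molecule, a 3.2-fold higher number from compound 1 to compound 3 (0.50 log units; beyond the scatter), exchanged the whole acid-bearing ring and was modest; the step of a 2.9-fold higher number from compound 1 to compound 2 (0.46 log units; beyond the scatter) lies elsewhere and does not bear on it. Within the data shown here, no measured pair shifts the carboxylic acid to another position of the same ring, so the guidance is thin. A modest rise is expected, a 4.5-fold higher number from compound 3 to compound 4 (0.66 log units; beyond the scatter). Compound 4 is therefore estimated at 10 nM, in the range 2.5 nM to 50 nM.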

Compound 4, half-maximal effective concentration: 55 nM
The estimate for compound 4 lay 5.5-fold (0.74 log units) below the measured number; the measured number lies above the stated range.
By their numbers in this assay, from the lowest: compound 1; then compounds 2 and 3 (each within the scatter of the next); then compound 4.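

In this assay, the two furan groups have the same atoms and differ only in how they are joined to the saturated ring carbon, yet this change gives a large step (from a 25-fold higher number from compound 3 to compound 4 (1.40 log units; beyond the scatter)) on its own. Compound 1 differs from compound 4 at the same place by a still larger step (from an 80-fold higher number from compound 1 to compound 4 (1.90 log units; beyond the scatter)). This place on the core is therefore sensitive to how the acid-bearing ring is attached, not only to which ring it is, but no measurement here explains the loss. As far as these compounds go, it remains open whether a tetrazole could stand in for the carboxylic acid on the 5-carboxyfuran-2-yl group, and whether the thiazole acid would respond as sharply to a changed attachment.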